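Aryl-substituted pyridine series: topoisomerase inhibition notes

This account rests on a few compounds, and the source may have more. Where it says the series, first, only, none or still open, it means among the compounds named here.

Measured compounds:
- compound 1 `Oc1cccc(-c2cc(-c3ccc(Cl)cc3)nc(-c3cccnc3)c2)c1`: 2.8%
- compound 2 `Oc1cccc(-c2cc(-c3ccc(Cl)cc3)nc(-c3ccsc3)c2)c1`: 11.7%
- compound 3 `Oc1ccc(-c2cc(-c3ccsc3)nc(-c3ccccc3Cl)c2)cc1`: 4.1%

All three were read in an assay on isolated protein for inhibition of DNA topoisomerase 1 (Homo sapiens), with a stated time of 30 min, tested at 100 uM; on this read-out lower numbers stand for a weaker effect and higher numbers for a stronger effect at the one concentration tested. Compound 2 and compound 1 differ by pyridin-3-yl in place of thiophen-3-yl on an aromatic carbon, and the step was a number 8.9 percentage points lower from compound 2 to compound 1 (within the scatter). Compound 3 carries the same atoms as compound 2 joined differently; the difference between the two cores is not broken down here. Compound 4 `Oc1ccc(-c2cc(-c3cccnc3)nc(-c3ccccc3Cl)c2)cc1` is not yet measured. It differs from compound 3 by pyridin-3-yl in place of thiophen-3-yl on an aromatic carbon, the same kind of change as from compound 2 to compound 1, though the surroundings of the place differ: there a 3-hydroxyphenyl group and a 4-chlorophenyl group, here a 2-chlorophenyl group and a 4-hydroxyphenyl group. Because the earlier step of a number 8.9 percentage points lower from compound 2 to compound 1 (within the scatter) lay within the scatter, a step of similar size is expected, a number 1.6 percentage points lower from compound 3 to compound 4 (within the scatter). Compound 4 is estimated at 2.5%, between 0% and 12%.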

Compound 4, a percentage reported as inhibition, at one concentration (the size of the read-out at that concentration, not a potency): 0.9%
Estimate against measurement, compound 4: 1.6 percentage points above; the range from low to high includes it.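

On the core of compound 3, pyridin-3-yl in place of thiophen-3-yl comes to a number 3.2 percentage points lower from compound 3 to compound 4 (within the scatter). Set beside the same change on the other core, the two steps do not differ: the same change on two cores in this assay, a number 8.9 percentage points lower (within the scatter) from compound 2 to compound 1 and a number 3.2 percentage points lower (within the scatter) from compound 3 to compound 4, 5.7 percentage points apart, within the scatter of two such steps. This shows that the change reads alike on both cores within the scatter, but with each step itself inside the scatter, it does not show that the change has a real effect on either core, nor that it would read the same on a further core.

The compounds shown leave open whether a group other than these two rings at this place, such as an amine or a carboxylic acid, would give a step beyond the scatter. Also open, going by these compounds, is how the series would read with a longer chain in place of the hydroxyl group.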